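The compounds below may be only part of what the source reports. "The series", "measured", "known", "first", "only" and "open" are said of these compounds alone.

Measured so far in a functional assay on MCF7 cells (Homo sapiens) for inhibition, read by MTT assay, with a stated time of 48 h; on this read-out higher numbers stand for weaker inhibition and lower numbers for stronger inhibition:

Compound 1 `COc1ccc(C(c2c[nH]c3ccc(Br)cc23)c2c[nH]c3ccc(Br)cc23)cc1` gives 2300 nM
Compound 2 `COc1ccc(OC)c(C(c2c[nH]c3ccc(Br)cc23)c2c[nH]c3ccc(Br)cc23)c1` gives 2800 nM
Compound 3 `Brc1ccc2[nH]cc(C(c3c[nH]c4ccc(Br)cc34)C3CCCCC3)c2c1` gives 4100 nM

Compound 3 does not stand apart from the other two in this assay, and no order can be read among the three. Its two steps, a 1.8-fold higher number from compound 1 to compound 3 (0.25 log units; within the scatter) and a 1.5-fold higher number from compound 2 to compound 3 (0.17 log units; within the scatter), tie it closely to both aromatic compounds.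

Compound 4 `Brc1ccc(C(c2c[nH]c3ccc(Br)cc23)c2c[nH]c3ccc(Br)cc23)cc1` has yet to be measured. Its change from compound 3 is 4-bromophenyl in place of cyclohexyl on a saturated chain carbon bound to two aromatic carbons.

The two steps above bear most directly on this, since they exchange an aromatic ring for cyclohexyl at that carbon, the opposite sense to the new change. A third step, a 1.2-fold higher number from compound 1 to compound 2 (0.09 log units; within the scatter), alters the groups on the aromatic ring while keeping the ring. None of compounds 1 to 3 carries 4-bromophenyl, so the range has to stay wide. Because a 1.8-fold higher number from compound 1 to compound 3 (0.25 log units; within the scatter) and a 1.5-fold higher number from compound 2 to compound 3 (0.17 log units; within the scatter) stay within the scatter, no step beyond the scatter is expected on returning to an aromatic ring.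

The expected step is a 1.6-fold lower number from compound 3 to compound 4 (0.21 log units; within the scatter) and it would leave the series closely grouped. The estimated value for compound 4 is 2500 nM with a range from 1000 nM to 6000 nM expected.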

Compound 4, half-maximal inhibitory concentration: 3200 nM
Estimate against measurement, compound 4: 1.3-fold (0.11 log units) below; the range from low to high includes it.
By their numbers in this assay, from the lowest: compounds 1, 2, 4 and 3 (each within the scatter of the next).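

At the saturated chain carbon bound to two aromatic carbons, in this assay, 4-bromophenyl in place of cyclohexyl gives a 1.3-fold lower number from compound 3 to compound 4 (0.11 log units; within the scatter) and does not set compound 4 apart from compound 3. The aromatic ring at this carbon need not carry methoxy for the number to stay in the same band: bromo in place of methoxy on an aromatic carbon gives a 1.4-fold higher number from compound 1 to compound 4 (0.14 log units; within the scatter) and the exchange of 2,5-dimethoxyphenyl for 4-bromophenyl gives a 1.1-fold higher number from compound 2 to compound 4 (0.06 log units; within the scatter) as well, so a cyclohexyl, two methoxy-bearing rings and a bromo-bearing ring now all lie within the scatter of one another at this position, and nothing at hand explains why these groups give such similar numbers.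

What the compounds shown leave open is whether any group at this carbon moves the number beyond the scatter, as an amine or a carboxylic acid on the phenyl ring, or a longer chain in place of the ring, might or might not. All four compounds also share the same bromo-bearing core, so they say nothing about how much of the activity depends on that core.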